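From Compound 1 to Compound 4 in Whole Blood

The source may report more compounds than this note shows. Statements on the series, on what has been measured and on what is new or still open speak of the compounds shown alone.

In a functional assay (blood) for inhibition, with Homo sapiens as the target (on this read-out higher numbers stand for weaker inhibition and lower numbers for stronger inhibition), compound 1 `C/C(=N\OC(=O)C(C)(C)C)c1ccc(Sc2cc(F)cc(C3CCOCC3)c2)cc1` gives 40 nM, the lowest of the three numbers. Compound 2 `COC(=O)c1cc(CO/N=C(\C)c2ccc(Sc3cc(F)cc(C4CCOCC4)c3)cc2)on1` gives 100 nM and compound 3 `CCOC(=O)c1csc(CO/N=C(\C)c2ccc(Sc3cc(F)cc(C4CCOCC4)c3)cc2)n1` gives 150 nM; the steps are a 2.5-fold higher number from compound 1 to compound 2 (0.40 log units; beyond the scatter), a 3.8-fold higher number from compound 1 to compound 3 (0.57 log units; beyond the scatter) and a 1.5-fold higher number from compound 2 to compound 3 (0.18 log units; within the scatter). Compound 4 `CC(=O)/C(=N\O)c1ccc(Sc2cc(F)cc(C3CCOCC3)c2)cc1` differs from compound 1 as follows: a group of 6 heavy atoms (3 carbon, 1 nitrogen, 2 oxygen; no ring) in place of a group of 10 heavy atoms (7 carbon, 1 nitrogen, 2 oxygen; no ring), on an aromatic carbon. Within the data shown here, no measured step replaces the group with one that has no ring and a hydrogen-bond donor; the measured steps only show that altering the group on the oxygen of compound 1 gave modestly higher numbers. The account therefore expects compound 4 to show a modest step in this assay, a 3.8-fold higher number from compound 1 to compound 4 (0.57 log units; beyond the scatter), toward a higher number, with wide uncertainty. Compound 4 is estimated at 150 nM, between 40 nM and 600 nM.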

Compound 4, half-maximal inhibitory concentration: 850 nM
Compound 4: middle estimate off by 5.7-fold (0.75 log units), on the low side, outside the stated range (above it).
By their numbers in this assay, from the lowest: compound 1; then compounds 2 and 3 (each within the scatter of the next); then compound 4.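

In this assay the change on the aromatic carbon gives a 21-fold higher number from compound 1 to compound 4 (1.33 log units; beyond the scatter) as a large step, while the earlier changes on the oxygen of compound 1 were only modest. Among these compounds, it is the first step that replaces the whole group on this carbon, para to a large group, rather than only what sits on the oxygen, and the read-out moves much further. No evidence at hand accounts for the size of this step. The compounds leave open whether the higher number goes with the hydrogen-bond donor or with the smaller group, and how an amine or a carboxylic acid on this carbon would read.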